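Compound 3 to compound 4: trading a ring for vinyl

The source may hold more compounds than are shown below. What is called first, only, known or untested is meant among the compounds shown, and "the series" means these compounds.

For the measured compounds named here, in a functional assay on HeLa cells (Homo sapiens) for inhibition (a lower number here means a stronger inhibitor of growth, a higher number a weaker inhibitor of growth), compound 3 `O=C1CC[C@@H](COC(=O)c2ccsc2NC(=O)[C@@H]2CCCN2)N1` gives 191 ug/mL as the only true number among the three compounds measured so far. Compound 1 `O=C(OCc1ccccc1)c1ccsc1NC(=O)[C@@H]1CCCN1` gives > 250 ug/mL as a limit of the assay and not a number. Compound 2 `O=C(OCC(Cl)(Cl)Cl)c1ccsc1NC(=O)[C@@H]1CCCN1` gives > 250 ug/mL as a limit too. The picture is framed by the limit of > 250 ug/mL in this assay, at which 2 of the 3 values shown sit, and little else.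

Compound 4 `C=CCOC(=O)c1ccsc1NC(=O)[C@@H]1CCCN1` keeps the shared core and differs from compound 3 by one change (vinyl in place of 5-oxopyrrolidin-2-yl on a saturated chain carbon bound to an oxygen next to a carbonyl group).

Going by the values given here, two measured steps bear on this place. Compound 4 gives up 5-oxopyrrolidin-2-yl, the group that came in with an at least 1.3-fold lower number from compound 1 to compound 3 (0.11 log units; that floor lies within the scatter) and with an at least 1.3-fold lower number from compound 2 to compound 3 (0.11 log units; that floor lies within the scatter) as the only sizes available, so a slightly higher number is expected, although both floors lie within the scatter. The remaining measured change is a step that the two limits leave unreadable from compound 1 to compound 2 and adds no size.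

In this assay the expected change is a 1.3-fold higher number from compound 3 to compound 4 (0.10 log units; within the scatter) and is estimated to stay within the scatter. Compound 4 is thus estimated at 240 ug/mL with an expected range of 120 ug/mL to 480 ug/mL around that value.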

Compound 4, concentration for 50% growth inhibition: 94.9 ug/mL
Compound 4: middle estimate off by 2.5-fold (0.40 log units), on the high side, and the stated range ends above it.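

Of the steps at this place in this assay, only two clear the scatter, and both bring in vinyl: an at least 2.6-fold lower number from compound 1 to compound 4 (0.42 log units; beyond the scatter) and an at least 2.6-fold lower number from compound 2 to compound 4 (0.42 log units; beyond the scatter). Both sizes are floors and not exact steps, because the values of compound 1 and compound 2 are limits of the assay and not numbers: the limit of > 250 ug/mL in this assay, at which 2 of the 4 values shown sit. The remaining step, a 2.0-fold lower number from compound 3 to compound 4 (0.30 log units; within the scatter), shows that vinyl, with no ring and no hydrogen-bond donor, cannot be told apart from 5-oxopyrrolidin-2-yl, so neither that ring nor its defined stereocentre is required for a readable number in this pair.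

The compounds shown leave open whether the double bond of vinyl matters or only the small size of the group, a question that an ethyl group at this place would address, while a longer chain or an amine on the chain would show how much else this place accepts. From the compounds shown here alone, all four compounds also share one core, so it remains unknown whether the same steps would hold with a different group on the other side of the ester.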